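A few compounds are considered here, and "the series" means these few. Any claim that something is new, unique, unknown or untested is made for them only; others in the source may bear on it.

In an ADME assay on SW1353 cells (Homo sapiens) for cytotoxicity, read by a luciferase reporter, with a stated time of 30 min (a lower number here means that less compound is tolerated, a higher number that more compound is tolerated), compound 1 (`CN(C(=O)c1ccc(-c2ccc(Cl)cc2)o1)c1ccc(N2CCNCC2)cc1`) is reported only as a limit, > 20000 nM. Among the measured compounds shown here, compound 2 (`CCCCN(C(=O)c1ccc(-c2ccc(Cl)cc2)o1)c1ccc(N2CCNCC2)cc1`), which carries a butyl chain, gives 19000 nM in this assay, and this is the single actual number so far.

Compound 3 (`O=C(c1ccc(-c2ccc(Cl)cc2)o1)N(Cc1ccncc1)c1ccc(N2CCNCC2)cc1`) has not yet been measured. Its structure departs from that of compound 2 by pyridin-4-yl in place of propyl on a saturated chain carbon bound to an amide-type nitrogen.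

For the measured compounds named here, only one measured step bears on this place, the exchange of hydrogen for propyl on that same kind of carbon, and it amounts to an at least 1.0-fold lower number from compound 1 to compound 2 (0.02 log units; that floor lies within the scatter). Going by the values given here, no measured step brings a ring into this position, so the evidence for the new group is thin. Among the compounds with values here, with only that small step as a guide, the change is not expected to move this assay beyond the scatter, in either direction. The expected change is a 1.1-fold lower number from compound 2 to compound 3 (0.02 log units; within the scatter). For compound 3 the estimate is 18000 nM, with an expected range of 9000 nM to 36000 nM.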

Compound 3, half-maximal cytotoxic concentration: > 8000 nM
Compound 3 was reported as a limit (the forecaster's own chance of this, stated with the estimate: 45%); the middle value does not contradict the limit.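

In this assay compound 3 is reported only as a limit, so the steps from compound 2 and from compound 1 to compound 3 cannot be read: the limit of > 8000 nM in this assay, at which 1 of the 3 values shown sits. The compounds shown leave open whether (pyridin-4-yl)methyl in place of butyl shifts the half-maximal cytotoxic concentration at all, and in which direction.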